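The compounds below may be only part of what the source reports. "The series", "measured", "known", "first", "only" and "open" are said of these compounds alone.

In an ADME assay on MDBK cells (Bos taurus) for cytotoxicity, read by MTT assay, with a stated time of 96 h (on this read-out higher numbers stand for lower toxicity in this test and lower numbers for higher toxicity in this test), compound 1 (`FC(F)(F)c1cccc(NC(=S)Nc2ccc(Cl)cc2)c1`) gives 17000 nM and compound 2 (`Fc1ccc(NC(=S)Nc2cccc(C(F)(F)F)c2)cc1`) gives 41000 nM as the higher of these two numbers. The next molecule, compound 3 (`C=C(C)CNC(=S)Nc1cccc(C(F)(F)F)c1`), keeps the rest of compound 2 and changes one substituent: 2-methylprop-2-en-1-yl in place of 4-fluorophenyl on an amide-type nitrogen. For the measured compounds named here, only one measured step offers any guide, a 2.4-fold higher number from compound 1 to compound 2 (0.38 log units; beyond the scatter) with fluoro in place of chloro on an aromatic carbon. That step is modest, and it exchanged only one halogen, whereas here the whole 4-fluorophenyl leaves, so it is a weak guide. A modest upward move is expected in this assay with a 2.2-fold higher number from compound 2 to compound 3 (0.34 log units; beyond the scatter) as the estimated size, though the direction is uncertain. For compound 3 the estimate is 90000 nM with an expected range from 35000 nM to 200000 nM around it.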

Compound 3, half-maximal cytotoxic concentration: > 100000 nM
Compound 3 gave a limit, no number; the forecaster's own chance of this, stated with the estimate: 35%; middle value at least 1.1-fold (0.04 log units) from the limit.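

In this assay compound 3 gives a limit of the assay and not a number: the limit of > 100000 nM in this assay, at which 1 of the 3 values shown sits.

Putting 2-methylprop-2-en-1-yl in place of the aromatic ring on the amide-type nitrogen gives an at least 2.4-fold higher number from compound 2 to compound 3 (0.38 log units; beyond the scatter) and an at least 5.8-fold higher number from compound 1 to compound 3 (0.76 log units; beyond the scatter), a move towards lower toxicity in this test. The earlier pair showed only what exchanging one halogen on that ring does, whereas these steps show that the whole 4-fluorophenyl or 4-chlorophenyl can leave without a rise in toxicity in this test.

The compounds shown cannot separate the loss of the aromatic ring from the arrival of the double bond, and a saturated chain such as 2-methylpropyl would be needed to tell these apart. They also leave open how a chain carrying an amine or a carboxylic acid at this nitrogen would read in this test.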